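Removing the methoxy group from compound 3

The source may report more compounds than this note shows. Statements on the series, on what has been measured and on what is new or still open speak of the compounds shown alone.

Values in an ADME assay on microsomes from liver (Homo sapiens) for metabolic stability, read by LC-MS, using NADPH, with a stated time of 30 min, tested at 3 uM; on this read-out lower numbers stand for a less stable compound and higher numbers for a more stable compound:
- compound 1 `CN1Cc2cc(-c3ccc(-c4cncc(NS(=O)(=O)c5ccc(F)cc5F)c4)s3)cnc2C1=O`: 80%
- compound 2 `CN1Cc2cc(-c3ccc(-c4cncc(NS(=O)(=O)c5cccc(C(F)(F)F)c5)c4)s3)cnc2C1=O`: 46%
- compound 3 `COc1ncc(-c2ccc(-c3cnc4c(c3)CN(C)C4=O)s2)cc1NS(=O)(=O)c1ccccc1C(F)(F)F`: 63%
- compound 4 `CN1Cc2cc(-c3ccc(-c4cncc(NS(=O)(=O)c5ccccc5C(F)(F)F)c4)s3)cnc2C1=O`: not yet measured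

Compound 3, at 63%, holds the middle place of the three numbers. It lies beyond the scatter from both compound 1 and compound 2.

The next step puts hydrogen in place of methoxy on an aromatic carbon, next to the ring nitrogen, and gives compound 4: hydrogen in place of methoxy on an aromatic carbon. Compound 4 keeps the sulfonyl group of compound 3 and has hydrogen on that carbon, as compound 1 and compound 2 do.

Within the data shown here, the only measured step is large: a number 34 percentage points lower from compound 1 to compound 2 (beyond the scatter). It lies at the sulfonyl sulfur, however, with 3-(trifluoromethyl)phenyl in place of 2,4-difluorophenyl. It shows how far a change at that place can move this assay, but it says nothing direct about the methoxy group. Among the measured compounds shown here, no measured pair isolates the methoxy group, so no direction can be drawn from the data, and no step beyond the scatter is expected.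

The expected change is a number 3 percentage points lower from compound 3 to compound 4 (within the scatter). For compound 4 the estimated value is 60%, with an expected range of 40% to 80%.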

Compound 4, percent of the compound remaining: 56%
Compound 4: the middle estimate sits 4 percentage points above what was measured, and the stated range covers the measured number.
By their numbers in this assay, from the lowest: compounds 2, 4 and 3 (each within the scatter of the next, the first and the last beyond it); then compound 1.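

In this assay the swap of methoxy for hydrogen on the aromatic carbon next to the ring nitrogen comes out as a number 7 percentage points lower from compound 3 to compound 4 (within the scatter) and so does not separate the two groups at this position, with 2-(trifluoromethyl)phenyl on the sulfonyl sulfur. With hydrogen on that carbon, the sulfonyl groups can now be compared directly: 2-(trifluoromethyl)phenyl in place of 3-(trifluoromethyl)phenyl is a number 10 percentage points higher from compound 2 to compound 4 (within the scatter) while 2-(trifluoromethyl)phenyl in place of 2,4-difluorophenyl is a number 24 percentage points lower from compound 1 to compound 4 (beyond the scatter) and counts as a real step. Among these compounds, then, the steps beyond the scatter lie at the sulfonyl sulfur, and the one step at the methoxy position does not.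

From the compounds shown here alone, whether hydrogen and methoxy stay this close with 2,4-difluorophenyl on the sulfonyl sulfur remains open, as does what an amine or a longer alkoxy chain would do on that aromatic carbon. No supporting measurement bears on the reasons behind these numbers.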